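The source may report more compounds than this note shows. Statements on the series, on what has been measured and on what is new or still open speak of the compounds shown alone.

Measured in a functional assay on MKN-74 cells (Homo sapiens) for inhibition, read by sulforhodamine B assay, with a stated time of 48 h; a higher number here means a weaker inhibitor of growth, a lower number a stronger inhibitor of growth:
- Compound 1 `CCCCCCCCCCCC[C@@H](O)[C@H]1CC[C@H]([C@H](O)CCCCCCCCCCNCc2ccnn2C)O1`: 1290 nM
- Compound 2 `CCCCCCCCCCCC[C@@H](O)[C@H]1CC[C@H]([C@H](O)CCCCCCCCCCC(=O)Nc2ccnn2C)O1`: 100000 nM

Compound 2, at 100000 nM, holds the higher of the two numbers, making it the weaker inhibitor of growth. Compound 3 `CCCCCCCCCCCC[C@@H](O)[C@H]1CC[C@H]([C@H](O)CCCCCCCCCCOC(=O)c2ccnn2C)O1` carries ((1-methyl-1H-pyrazol-5-yl)carbonyl)oxy in place of (1-methyl-1H-pyrazol-5-yl)carbamoyl on a saturated chain carbon, ten or more bonds along the chain from an oxygen on a saturated carbon and a saturated ring carbon. Within the data shown here, the only measured step at this place, a 78-fold higher number from compound 1 to compound 2 (1.89 log units; beyond the scatter), is large, so a swap here can move the number far. Among the measured compounds shown here, no measured compound carries this new group, so the size stays uncertain. A moderate fall is expected, with an estimated 6.7-fold lower number from compound 2 to compound 3 (0.82 log units; beyond the scatter). Compound 3 is expected near 15000 nM, with an estimated range of 2500 nM to 100000 nM.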

Compound 3, concentration for 50% growth inhibition: 30900 nM
For compound 3 the middle estimate is 2.1-fold (0.31 log units) below the measured one; the range from low to high includes it.
By their numbers in this assay, from the lowest: compound 1; then compound 3; then compound 2.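

Putting ((1-methyl-1H-pyrazol-5-yl)carbonyl)oxy in place of (1-methyl-1H-pyrazol-5-yl)carbamoyl gives a 3.2-fold lower number from compound 2 to compound 3 (0.51 log units; beyond the scatter), so the link at this place still affects growth inhibition when the carbonyl is kept. The step of a 24-fold higher number from compound 1 to compound 3 (1.38 log units; beyond the scatter) is much larger, so both carbonyl-containing links remain far weaker than the ((1-methyl-1H-pyrazol-5-yl)methyl)amino group. No available evidence explains either step. From the compounds shown here alone, it remains open whether the amine nitrogen itself matters, and a methylated amine or a plain ether link at this place would test that.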